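Catechol for Dimethoxy on a Secoiridoid Glycoside Ester

The compounds below may be only part of what the source reports. "The series", "measured", "known", "first", "only" and "open" are said of these compounds alone.

Measured so far in a functional assay on SK-BR-3 cells (Homo sapiens) for antiproliferative activity, read by MTT assay, with a stated time of 72 h; a lower number here means a stronger inhibitor, a higher number a weaker inhibitor:
- compound 1 `C/C=C1/[C@H](O[C@@H]2O[C@H](COC(C)=O)[C@@H](OC(C)=O)[C@H](OC(C)=O)[C@H]2OC(C)=O)OC=C(C(=O)OC)[C@H]1CC(=O)SCCc1ccccc1`: a limit, > 15000 nM
- compound 2 `C/C=C1/[C@H](O[C@@H]2O[C@H](CO)[C@@H](O)[C@H](O)[C@H]2O)OC=C(C(=O)OC)[C@H]1CC(=O)OCCc1ccc(OC)c(OC)c1`: a limit, > 15000 nM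
- compound 3 `C/C=C1/[C@H](O[C@@H]2O[C@H](COC(C)=O)[C@@H](OC(C)=O)[C@H](OC(C)=O)[C@H]2OC(C)=O)OC=C(C(=O)OC)[C@H]1CC(=O)OC`: a limit, > 15000 nM

Every value shown is a limit rather than a number, so compound 2 stands where all three stand, at the limit of > 15000 nM in this assay, at which 3 of the 3 values shown sit. The only one-place step shown, a step that the two limits leave unreadable from compound 1 to compound 3, cannot be read for size. Compound 4 `C/C=C1/[C@H](O[C@@H]2O[C@H](CO)[C@@H](O)[C@H](O)[C@H]2O)OC=C(C(=O)OC)[C@H]1CC(=O)OCCc1ccc(O)c(O)c1` differs from compound 2 by 3,4-dihydroxyphenyl in place of 3,4-dimethoxyphenyl on a saturated chain carbon, two bonds along the chain from an oxygen next to a carbonyl group. Within the data shown here, no measured step covers this change, and with every compound at the limit no direction can be drawn from the data. The expected step from compound 2 is therefore a step that the limit leaves unreadable from compound 2 to compound 4, meaning none beyond the scatter. Compound 4 is expected to give 20000 nM in this assay, in a range from 7000 nM to 60000 nM, most likely again as a limit.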

Compound 4, half-maximal inhibitory concentration: 160000 nM
The estimate for compound 4 lay 8.0-fold (0.90 log units) below the measured number, and the stated range ends below it.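

No size can be read for the change from compound 2 to compound 4, because compound 2 is recorded only as a limit: the limit of > 15000 nM in this assay, at which 3 of the 4 values shown sit.

The compounds shown leave open whether 3,4-dihydroxyphenyl in place of 3,4-dimethoxyphenyl changes activity in this assay at all.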